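The compounds below may be only part of what the source reports. "The series", "measured", "known", "first", "only" and "open" are said of these compounds alone.

Working notes on the series. Compound 1 `Nc1nc(N)c(Br)c(OCc2ccccc2)n1` and compound 2 `Fc1nc(OCc2ccccc2)c2[nH]cnc2n1` have both been measured in an assay on HT-29 cells with Methylated-DNA--protein-cysteine methyltransferase (Homo sapiens) as the target, with a stated time of 4 h; a higher number here means that more compound is needed for the effect, a lower number that less compound is needed. Compound 1 gives 0.8 uM, while compound 2 gives 12 uM, the highest of the two numbers and a gap beyond the scatter. The next member, compound 3 `CN(C)c1nc(OCc2ccccc2)c2[nH]cnc2n1`, differs from compound 2 by dimethylamino in place of fluoro on an aromatic carbon. Among the measured compounds shown here, no measured pair shows this exchange, so no size of step can be read from the data; an expected step from compound 2 to compound 3 of a 1.3-fold higher number from compound 2 to compound 3 (0.10 log units; within the scatter) is taken as the working guess, essentially none beyond the scatter. Compound 3 is thus expected to give 15 uM, within a range from 4 uM to 50 uM.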

Compound 3, concentration for half-maximal effect: 110 uM
Estimate against measurement, compound 3: 7.3-fold (0.87 log units) below, and the stated range ends below it.
By their numbers in this assay, from the lowest: compound 1; then compound 2; then compound 3.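

This position, on an aromatic carbon between two ring nitrogen atoms, responds clearly to substitution: dimethylamino in place of fluoro gives a 9.2-fold higher number from compound 2 to compound 3 (0.96 log units; beyond the scatter) in this assay. The exchange adds heavy atoms and a hydrogen-bond acceptor, but this single pair cannot separate those changes. No measurement at hand accounts for the size of the step. Going by these compounds, it remains open whether methylamino or methoxy at this position would stay close to compound 2 or follow compound 3. Compound 1 differs from both in more than one place and does not settle this.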